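The source may report more compounds than this note shows. Statements on the series, on what has been measured and on what is new or still open speak of the compounds shown alone.

In a functional assay on A549 cells (Homo sapiens) for antiproliferative activity, read by MTT assay, with a stated time of 72 h (a lower number here means a stronger inhibitor, a higher number a weaker inhibitor), the measured compounds are:
Compound 1 `O=C(N/N=C/c1ccc(Br)cc1)Nc1ccc(Oc2ccnc3[nH]ccc23)c(F)c1` gives 820 nM
Compound 2 `O=C(N/N=C/c1ccc(Br)cc1)Nc1ccc(Oc2ccnc3[nH]ccc23)cc1` gives 640 nM

Among the measured compounds shown here, only one step has been measured, a 1.3-fold lower number from compound 1 to compound 2 (0.11 log units; within the scatter), so compound 2 stands level with its sole neighbour. Compound 3 `O=C(N/N=C/c1cccc(Cl)c1Cl)Nc1ccc(Oc2ccnc3[nH]ccc23)cc1` has 2,3-dichlorophenyl in place of 4-bromophenyl on a carbon with a double bond to nitrogen. The measured step changes a different place and gives no guide to this swap, so no step beyond the scatter is expected in this assay, and no direction can be given. The expected step is a 1.1-fold lower number from compound 2 to compound 3 (0.03 log units; within the scatter). For compound 3 the estimated value is 600 nM, with an expected range of 200 nM to 1800 nM.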

Compound 3, half-maximal inhibitory concentration: "not active" (no number reported)
The entry for compound 3 holds no number; there is nothing to compare the estimate with.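

In this assay, among the compounds shown here, compound 3 is reported as "not active" with no number, so no step from compound 2 to compound 3 can be read. The compounds shown leave open how far 2,3-dichlorophenyl in place of 4-bromophenyl shifts the activity, and no measured evidence bears on this result.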